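Working notes on the shared-core series, compound 3 to compound 4

The source may report more compounds than this note shows. Statements on the series, on what has been measured and on what is new or still open speak of the compounds shown alone.

Of the compounds shown here, three of the shared core have been measured. In a functional assay on HepG2 cells (Homo sapiens) for inhibition, read by MTT assay, with a stated time of 72 h (on this read-out lower numbers stand for stronger inhibition and higher numbers for weaker inhibition), compound 1 `CCCCCCCCc1cn(Cc2cc(=O)oc3cc(O)ccc23)nn1` gives 34200 nM, compound 2 `CCCCc1ccc(-c2cn(Cc3cc(=O)oc4cc(O)ccc34)nn2)cc1` gives 48400 nM and compound 3 `Cc1ccc(S(=O)(=O)NCc2cn(Cc3cc(=O)oc4cc(O)ccc34)nn2)cc1` gives 29800 nM. Compound 3 has the lowest number of the three, but its gaps to compound 1 and to compound 2 both lie within the scatter, so no order among them can be stated. Compound 4 `O=c1cc(Cn2cc(CNS(=O)(=O)c3ccc([N+](=O)[O-])cc3)nn2)c2ccc(O)cc2o1` is not yet measured; it differs from compound 3 by nitro in place of methyl on an aromatic carbon. Among the measured compounds shown here, no step between measured compounds bears on this change, and the three numbers so far sit close together, so in this assay no step beyond the scatter is expected in either direction. The step of a 1.0-fold higher number from compound 3 to compound 4 (0.00 log units; within the scatter) is expected to stay within the scatter. For compound 4 the estimated value is 30000 nM, within a range of 12000 nM to 75000 nM.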

Compound 4, half-maximal inhibitory concentration: > 100000 nM
Compound 4: no number, only a limit; the forecaster's own chance of this, stated with the estimate: 10%; middle value at least 3.3-fold (0.52 log units) from the limit.
By their numbers in this assay, from the lowest: compounds 3, 1 and 2 (each within the scatter of the next). At a limit, above all of these: compound 4.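

In this assay, among the compounds shown here, 4-methylphenyl to 4-nitrophenyl gives an at least 3.3-fold higher number from compound 3 to compound 4 (0.52 log units; beyond the scatter), the only step that lies beyond the scatter. For the compounds shown here, the aromatic carbon para to a large group is therefore not indifferent to the group it carries, which the earlier compounds could not show. The reading for compound 4 is a limit of the assay and not a number: the limit of > 100000 nM in this assay, at which 1 of the 4 values shown sits.

Going by these compounds, the full size of the step stays open. So does whether an amine or a chlorine on the same aromatic carbon would keep the number near that of compound 3.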